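A few compounds are considered here, and "the series" means these few. Any claim that something is new, unique, unknown or untested is made for them only; others in the source may bear on it.

In a functional assay on NCI-H1975 cells (Homo sapiens) for cytotoxicity, read by MTT assay, with a stated time of 72 h (a lower number here means a stronger inhibitor, a higher number a weaker inhibitor), compound 1 (`Cc1cc(C)cc(-n2c(Nc3ccccc3)nc3cnc(Nc4ccc(N5CCN(C)CC5)cc4)nc32)c1`) reads 1910 nM and compound 2 (`CC1CCN(c2ccc(Nc3ncc4nc(Nc5ccccc5)n(C5CCCC5)c4n3)cc2)CC1`) reads 9800 nM in the same series. Compound 3 (`CN1CCN(c2ccc(Nc3ncc4nc(Nc5cccc([N+](=O)[O-])c5)n(C5CCCC5)c4n3)cc2)CC1`) reads 980 nM and so lies within the scatter of compound 1 and clearly under compound 2, with that second gap beyond the scatter. For the measured compounds named here, the three compounds differ from one another in more than one place, so no measured step isolates a single change.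

Compound 4 (`CN1CCN(c2ccc(Nc3ncc4nc(Nc5ccc(Br)cc5F)n(C5CCCC5)c4n3)cc2)CC1`) has not yet been measured. Against compound 3 it shows one change (4-bromo-2-fluorophenyl in place of 3-nitrophenyl on a nitrogen on an aromatic ring), namely 4-bromo-2-fluorophenyl in place of 3-nitrophenyl on a nitrogen on an aromatic ring, with the rest of the structure the same.

Going by the values given here, with no measured step for this replacement, the expectation rests on compound 3 as the anchor (980 nM) and on compound 2 as the upper reach of the series so far (9800 nM). A small move toward a weaker number is expected (a 1.5-fold higher number from compound 3 to compound 4 (0.18 log units; within the scatter)), and this estimated step stays within the scatter. Among the compounds with values here, no measured compound carries the entering group, so the range is kept wide. For compound 4 the estimate is 1500 nM with an expected range (500 nM to 5000 nM).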

Compound 4, half-maximal inhibitory concentration: 1120 nM
The estimate for compound 4 lay 1.3-fold (0.13 log units) above the measured number; the range from low to high includes it.
By their numbers in this assay, from the lowest: compounds 3, 4 and 1 (each within the scatter of the next); then compound 2.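

In this assay, for the compounds shown here, 4-bromo-2-fluorophenyl in place of 3-nitrophenyl on a nitrogen on an aromatic ring gives a 1.1-fold higher number from compound 3 to compound 4 (0.06 log units; within the scatter), the first measured step that isolates a single change. The two groups share a six-membered aromatic ring of carbon only but differ in their substituents: the hydrogen-bond acceptors counted on 3-nitrophenyl are absent from 4-bromo-2-fluorophenyl, yet this pair of compounds still reads alike, so a reading at this level does not depend on those acceptors here. Nothing at hand explains this match or shows what the cell read-out reflects at this position.

The compounds shown leave open what each halogen contributes on its own, since 4-bromo-2-fluorophenyl carries bromine and fluorine together and neither a 4-bromophenyl nor a 2-fluorophenyl partner appears alongside it. They also leave open whether the same flat reading holds for a ring bearing a carboxylic acid or a primary amine, or for a saturated group such as cyclohexyl in place of the aromatic ring on this nitrogen.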